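A few compounds are considered here, and "the series" means these few. Any claim that something is new, unique, unknown or untested is made for them only; others in the source may bear on it.

Compound 1, `Cc1nnc(N2CCC(C(=O)N3N=CC[C@H]3c3ccccc3)CC2)o1`: 2.88 h
Compound 2, `Cc1nnc(N2CCC(C(=O)N3N=CC[C@H]3c3cc(F)cc(F)c3)CC2)o1`: 3.3 h

Among the measured compounds shown here, in an ADME assay on cells (Hepatocyte, Rattus norvegicus) for metabolic stability (a lower number here means that the compound disappears faster, a higher number that the compound lasts longer), compound 1 holds the lowest of the two numbers measured so far, and its nearest neighbour is compound 2, which gives 3.3 h. For the measured compounds named here, the one measured step, a 1.1-fold higher number from compound 1 to compound 2 (0.06 log units; within the scatter), comes from putting 3,5-difluorophenyl in place of phenyl on a saturated ring carbon and leaves the read-out essentially unchanged.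

Compound 3, `O=C(C1CCN(c2ccccn2)CC1)N1N=CC[C@H]1c1ccccc1`, has not yet been measured in this assay. It differs from compound 1 in one place: pyridin-2-yl in place of 5-methyl-1,3,4-oxadiazol-2-yl on an amine nitrogen in a ring. Going by the values given here, the only measured step in this set alters the group on the saturated ring carbon, not the group on the amine nitrogen in a ring, so it does not bear on the change from compound 1 to compound 3. Among the compounds with values here, with no measured step covering an exchange of this kind, the size and direction of any shift remain open, and the expectation is anchored on compound 1 alone, with a broad range around it.

For compound 3 the estimated half-life in this assay is 2.6 h, with a range from 1 h to 6.5 h. This estimate corresponds to a 1.1-fold lower number from compound 1 to compound 3 (0.04 log units; within the scatter), which is expected to lie within the scatter of compound 1.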

Compound 3, half-life: 0.0633 h
Beside the measured number, compound 3's estimate is 41-fold (1.61 log units) above it; the measured number lies below the stated range.
By their numbers in this assay, from the lowest: compound 3; then compounds 1 and 2 (each within the scatter of the next).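

In this assay, among the compounds shown here, the group on the amine nitrogen in a ring proves to be a highly sensitive point of the molecule: pyridin-2-yl in place of 5-methyl-1,3,4-oxadiazol-2-yl gives a 45-fold lower number from compound 1 to compound 3 (1.66 log units; beyond the scatter), whereas the only earlier step, on the saturated ring carbon, gave a 1.1-fold higher number from compound 1 to compound 2 (0.06 log units; within the scatter). The large shift arises although the two groups have the same count of 6 heavy atoms, and neither carries a net charge or a hydrogen-bond donor; they differ in ring size, in hetero atoms and in hydrogen-bond acceptors. Nothing available explains why this exchange has so large an effect on the half-life.

The compounds shown leave open which of those differences goes with the shift, a question that a pyrimidin-2-yl or a 1,3,4-thiadiazol-2-yl group on the same nitrogen could help to separate. They also leave open whether 3,5-difluorophenyl in place of phenyl, a change that stays within the scatter when 5-methyl-1,3,4-oxadiazol-2-yl is present, would remain as silent with pyridin-2-yl in its place.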